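This account rests on a few compounds, and the source may have more. Where it says the series, first, only, none or still open, it means among the compounds named here.

Measured compounds in a functional assay on CCRF-CEM cells (Homo sapiens) for inhibition, read by cell counting, with a stated time of 3 days; on this read-out higher numbers stand for weaker inhibition and lower numbers for stronger inhibition:
compound 1 `C=C(Br)C(=O)Nc1cccc(-c2cn3nc(Cc4cccc(OC)c4)sc3n2)c1` gives 3100 nM
compound 2 `C=C(Br)C(=O)Nc1cccc(-c2cn3nc(Cc4ccccc4)sc3n2)c1` gives 4200 nM
compound 3 `Nc1cccc(-c2cn3nc(Cc4ccccc4)sc3n2)c1` gives 37000 nM

Compound 3 stands highest of these three numbers in this assay: the step of an 8.8-fold higher number from compound 2 to compound 3 (0.94 log units; beyond the scatter) is beyond the scatter, and compound 1 sits lower again. Compound 4 `COc1cccc(Cc2nn3cc(-c4cccc(N)c4)nc3s2)c1` differs from compound 3 by methoxy in place of hydrogen on an aromatic carbon. For the measured compounds named here, the one measured step that bears on this change is a 1.4-fold higher number from compound 1 to compound 2 (0.13 log units; within the scatter), which runs the other way, hydrogen in place of methoxy, and stays within the scatter. The bromoethenyl amide removed in an 8.8-fold higher number from compound 2 to compound 3 (0.94 log units; beyond the scatter) is absent from both compound 3 and compound 4, so that step does not bear here. The expected step is therefore a 1.3-fold lower number from compound 3 to compound 4 (0.12 log units; within the scatter), nothing beyond the scatter. Compound 4 is estimated at 28000 nM, with a range from 12000 nM to 65000 nM.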

Compound 4, half-maximal inhibitory concentration: 40000 nM
Beside the measured number, compound 4's estimate is 1.4-fold (0.15 log units) below it, and the stated range covers the measured number.
By their numbers in this assay, from the lowest: compounds 1 and 2 (each within the scatter of the next); then compounds 3 and 4 (each within the scatter of the next).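

In this assay, methoxy in place of hydrogen on this aromatic carbon still makes no clear difference once the bromoethenyl amide is gone, a 1.1-fold higher number from compound 3 to compound 4 (0.03 log units; within the scatter), and the same holds on both cores: the same change on two cores in this assay, a 1.4-fold higher number (0.13 log units; within the scatter) from compound 1 to compound 2 and a 1.1-fold lower number (0.03 log units; within the scatter) from compound 4 to compound 3, 1.5-fold (0.17 log units) apart, within the scatter of two such steps. Losing the (1-bromoethenyl)carbonyl group from the nitrogen, a 13-fold higher number from compound 1 to compound 4 (1.11 log units; beyond the scatter), costs a similar amount with methoxy present as without it: the same change on two cores in this assay, an 8.8-fold higher number (0.94 log units; beyond the scatter) from compound 2 to compound 3 and a 13-fold higher number (1.11 log units; beyond the scatter) from compound 1 to compound 4, 1.5-fold (0.17 log units) apart, within the scatter of two such steps.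

As far as these compounds go, whether a different group at this place, such as an amine or a carboxylic acid, would move the number remains open. So does whether a plain acetyl on the nitrogen would keep the stronger inhibition seen with the bromoethenyl amide.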